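Solubility notes: fluorophenyl for dimethylaminophenyl ether swap

This account rests on a few compounds, and the source may have more. Where it says the series, first, only, none or still open, it means among the compounds named here.

Compound 1 `CN(C)c1cccc(Oc2ccc3c(NCCCNCc4ccco4)ccnc3c2)c1` gives 14500 nM in a physicochemical assay for solubility, with a stated time of 18 h, at pH 7.4; on this read-out lower numbers stand for lower solubility and higher numbers for higher solubility. Compound 2 `Fc1ccc(Oc2ccc3c(NCCCNCc4ccco4)ccnc3c2)cc1` gives 14500 nM in this assay, and compound 3 `COc1cccc(CNCCCNc2ccnc3cc(Oc4cccc(N(C)C)c4)ccc23)c1O` gives 14500 nM. The change 4-fluorophenyl in place of 3-(dimethylamino)phenyl on an oxygen on an aromatic ring made no change at the digits printed from compound 1 to compound 2 (within the scatter). The cores of compound 1 and compound 3 differ by 2-hydroxy-3-methoxyphenyl in place of furan-2-yl on a saturated chain carbon bound to an amine nitrogen, with no change at the digits printed from compound 1 to compound 3 (within the scatter). Compound 4 `COc1cccc(CNCCCNc2ccnc3cc(Oc4ccc(F)cc4)ccc23)c1O` is not yet measured in this assay; it differs from compound 3 by 4-fluorophenyl in place of 3-(dimethylamino)phenyl on an oxygen on an aromatic ring, the same change as from compound 1 to compound 2, at a place described in identical words. Nothing among these three measured compounds separates them in this assay. The step is expected to be no change at the digits printed from compound 3 to compound 4 (within the scatter) because no change at the digits printed from compound 1 to compound 2 (within the scatter) was the outcome of the same change. Compound 4 is therefore estimated at 14500 nM, with an expected range from 7000 nM to 29000 nM.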

Compound 4, solubility: 14500 nM
Estimate against measurement, compound 4: no gap at the digits printed, within the range that was stated.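

On the core of compound 3, the change of 4-fluorophenyl in place of 3-(dimethylamino)phenyl gave no change at the digits printed from compound 3 to compound 4 (within the scatter) in this assay, the same outcome as no change at the digits printed from compound 1 to compound 2 (within the scatter), and the difference in the other place gave no change at the digits printed from compound 2 to compound 4 (within the scatter), so the four compounds form a closed square with no step beyond the scatter. Within the data shown here, this shows that the change carried across these two cores with no visible shift, but it does not show that it would do so on any other core, and with no step to compare in size, it cannot show that an effect transfers. No measurement here gives a reason for the identical values.

Still open, from the compounds shown here alone, is how a carboxylic acid or an amine in place of the 4-fluorophenyl would read in this assay. Going by these compounds, a longer chain in place of the saturated chain is equally open.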